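Hydrogen in place of tert-butyl on compound 2

A few compounds are considered here, and "the series" means these few. Any claim that something is new, unique, unknown or untested is made for them only; others in the source may bear on it.

Measured in a functional assay on HCT-116 cells (Homo sapiens) for antiproliferative activity, read by MTT assay, with a stated time of 72 h; a lower number here means a stronger inhibitor, a higher number a weaker inhibitor:
Compound 1 `C=CC(=O)N(CC(=O)OC)c1nc(-c2ccccc2)cs1` gives > 30000 nM as a limit of the assay
Compound 2 `C=CC(=O)N(CC(=O)OC(C)(C)C)c1nc(-c2ccccc2)cs1` gives 20900 nM as an actual number

In this assay, among the measured compounds shown here, compound 2 at 20900 nM holds the only actual number so far. The value of compound 1 is a limit and not a number (the limit of > 30000 nM in this assay, at which 1 of the 2 values shown sits). Compound 3 `C=CC(=O)N(CC(=O)O)c1nc(-c2ccccc2)cs1` carries hydrogen in place of tert-butyl on an oxygen next to a carbonyl group. For the measured compounds named here, only one measured step bears on this place (an at least 1.4-fold lower number from compound 1 to compound 2 (0.15 log units; that floor lies within the scatter)), and it exchanges methyl for tert-butyl, so it offers no direct case of hydrogen there. Resting on that step and on compound 2 (20900 nM), a small move to a higher number is expected in this assay. For compound 3 a report of only a limit is quite possible. The expected change is modest (a 1.7-fold higher number from compound 2 to compound 3 (0.22 log units; within the scatter)). For compound 3 the estimated value is 35000 nM (expected range 15000 nM to 90000 nM).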

Compound 3, half-maximal inhibitory concentration: > 30000 nM
Compound 3 was reported as a limit (the forecaster's own chance of this, stated with the estimate: 60%); the middle value is on the limit's open side.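

In this assay, among the compounds shown here, compound 3 gives > 30000 nM, which is a limit and not a number, and it is the first case here with hydrogen rather than a carbon group on this oxygen. The change reads as an at least 1.4-fold higher number from compound 2 to compound 3 (0.15 log units; that floor lies within the scatter), so the floor of this step does not separate the carboxymethyl compound from the (tert-butoxycarbonyl)methyl compound. The step between compound 1 and compound 3 cannot be read, as both values are limits, and the limit now recurs across the series: the limit of > 30000 nM in this assay, at which 2 of the 3 values shown sit.

Going by these compounds, how far the true value of compound 3 lies from that of compound 2 stays open. Also open, on these data alone, is how an isopropyl or benzyl group on this oxygen, or a primary amide in place of the ester, would read in this assay.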